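The source may hold more compounds than are shown below. What is called first, only, known or untested is meant among the compounds shown, and "the series" means these compounds.

Of the compounds shown here, two have so far been measured in a functional assay on WHCO1 cells (Homo sapiens) for cytotoxicity, read by MTT assay, with a stated time of 24 h; on this read-out higher numbers stand for weaker inhibition and lower numbers for stronger inhibition. Compound 1 `C=CC(O)C1=CC(=O)c2ccccc2C1=O` gives 4300 nM, and compound 2 `O=C1C=C(C(O)c2ccccc2)C(=O)c2ccccc21` gives 3900 nM. The step between them was a 1.1-fold lower number from compound 1 to compound 2 (0.04 log units; within the scatter). Compound 2 stands at the lower of the two numbers, with compound 1 within the scatter of it. Compound 3 `O=C1C=C(C(O)c2cccc(F)c2)C(=O)c2ccccc21` differs from compound 2 by fluoro in place of hydrogen on an aromatic carbon. Among the compounds with values here, the single step seen so far concerned a different part of the molecule and barely moved the number; no step shows fluoro in place of hydrogen on an aromatic carbon, so the expected step is no change at the digits printed from compound 2 to compound 3 (within the scatter), nothing beyond the scatter. Compound 3 is therefore estimated at 3900 nM, between 2000 nM and 7500 nM.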

Compound 3, half-maximal inhibitory concentration: 5500 nM
Compound 3: middle estimate off by 1.4-fold (0.15 log units), on the low side; low and high end bracket the measured number.
By their numbers in this assay, from the lowest: compounds 2, 1 and 3 (each within the scatter of the next).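

Fluoro in place of hydrogen on the phenyl ring gives a 1.4-fold higher number from compound 2 to compound 3 (0.15 log units; within the scatter) in this assay, so this first change on the aromatic ring leaves the number within the scatter. Putting 3-fluorophenyl in place of vinyl gives a 1.3-fold higher number from compound 1 to compound 3 (0.11 log units; within the scatter) and likewise stays within the scatter. No measurement is available to explain these results.

On these data alone, whether another group on this ring carbon, such as an amine or a carboxylic acid, would move the number beyond the scatter remains open. So does the effect of fluoro on the other ring carbons.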